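The source may report more compounds than this note shows. Statements on the series, on what has been measured and on what is new or still open speak of the compounds shown alone.

In a functional assay on A2780 cells (Homo sapiens) for antiproliferative activity, read by CellTiter-Glo, with a stated time of 72 h (a higher number here means a weaker inhibitor, a lower number a stronger inhibitor), three compounds have been measured. Compound 1 (`C[C@H](NC(=O)c1ncccn1)c1ccc(NC(=O)N2CC(c3cccnc3)C2)cc1`) gives 36 nM and compound 2 (`C[C@@H](c1ccc(NC(=O)N2CC(c3cncc(N)c3)C2)cc1)N1Cc2ccccc2C1=O`) gives 45 nM. Compound 3 (`C[C@H](NC(=O)c1cccc(F)c1)c1ccc(NC(=O)N2CC(c3cncc(N)c3)C2)cc1`) gives 240 nM, the highest of the three numbers, which makes it the weakest inhibitor of the set.

Compound 4 (`C[C@H](NC(=O)c1ncccn1)c1ccc(NC(=O)N2CC(c3cncc(N)c3)C2)cc1`) departs from compound 3 in one place: pyrimidin-2-yl in place of 3-fluorophenyl on a carbonyl carbon. In short, pyrimidin-2-yl stands in place of 3-fluorophenyl on a carbonyl carbon.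

Within the data shown here, no measured step covers this exact change. Among the measured compounds shown here, the only step between measured compounds is a 5.3-fold higher number from compound 2 to compound 3 (0.73 log units; beyond the scatter), a modest move beyond the scatter. It shows that the number responds to a change on this side of the molecule, but it involves a different group and a different attachment point. The closest evidence is compound 1, which carries the same pyrimidin-2-yl on a carbonyl carbon and gives 36 nM, although it differs from compound 4 elsewhere. That value, set against 240 nM for compound 3, points towards a lower number, and the mismatch between the structures argues for caution.

The expected move is a 3.4-fold lower number from compound 3 to compound 4 (0.54 log units; beyond the scatter), towards stronger inhibition. For compound 4 the estimated value is 70 nM, with an expected range from 25 nM to 200 nM.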

Compound 4, half-maximal inhibitory concentration: 340 nM
Compound 4: middle estimate off by 4.9-fold (0.69 log units), on the low side; the measured number lies above the stated range.
By their numbers in this assay, from the lowest: compounds 1 and 2 (each within the scatter of the next); then compounds 3 and 4 (each within the scatter of the next).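

In this assay, pyrimidin-2-yl and 3-fluorophenyl on a carbonyl carbon could not be told apart when the amino group was present (a 1.4-fold higher number from compound 3 to compound 4 (0.15 log units; within the scatter)), so this change alone did not shift the number beyond the scatter. The pair that shares pyrimidin-2-yl showed that the value depends strongly on another site, with amino in place of hydrogen on an aromatic carbon accounting for the whole difference (a 9.4-fold higher number from compound 1 to compound 4 (0.98 log units; beyond the scatter)); the low value of compound 1 therefore did not carry over to its amino counterpart. Replacing the group on the saturated chain carbon in compound 2 with the pyrimidin-2-yl amide also gave a step beyond the scatter (a 7.6-fold higher number from compound 2 to compound 4 (0.88 log units; beyond the scatter)), so both amides shown with the amino group lie on the same side of compound 2.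

Nothing shown here explains why these numbers move as they do. From the compounds shown here alone, it remains open whether amino in place of hydrogen has a similar effect alongside 3-fluorophenyl, and whether a saturated amine such as morpholine or a small alkyl group such as methyl on the carbonyl carbon would separate from the two groups compared here.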